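Liver microsome half-life notes on a sulfonyl hydrazide series

A few compounds are considered here, and "the series" means these few. Any claim that something is new, unique, unknown or untested is made for them only; others in the source may bear on it.

Measured so far:
- compound 1, `Cc1cc(-n2nccn2)cc(C(=O)NNS(=O)(=O)c2ccccc2)c1F`: 1.02 h
- compound 2, `O=C(NNS(=O)(=O)c1ccccc1F)c1cccc(-n2cccn2)c1`: 2.35 h

In an ADME assay on microsomes from liver (Homo sapiens) for metabolic stability, read by HPLC, using NADPH, with a stated time of 60 min, tested at 1 uM, in the presence of a further agent that is not named here (on this read-out higher numbers stand for a longer-lived compound and lower numbers for a shorter-lived compound), compound 1 gives 1.02 h and stands lowest of the two numbers. Within the data shown here, the nearest is compound 2, which in this assay gives 2.35 h; the gap between the two values lies beyond the scatter, but compound 2 differs from compound 1 in more than one place, so no single step is assigned to that pair.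

Compound 3, `Cc1cc(-n2cccn2)cc(C(=O)NNS(=O)(=O)c2ccccc2)c1F`, is not yet measured. It differs from compound 1 in one place: 1H-pyrazol-1-yl in place of 2H-1,2,3-triazol-2-yl on an aromatic carbon. Among the measured compounds shown here, no measured pair shows this change on its own. Given that compound 2, which carries the entering group, gives 2.35 h, a small rise is expected, though one that may stay within the scatter. Compound 3 is expected to give 1.35 h (range 0.65 h to 2.8 h), an estimated step of a 1.3-fold higher number from compound 1 to compound 3 (0.12 log units; within the scatter).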

Compound 3, half-life in the Homo sapiens assay: 1.25 h
Compound 3: the middle estimate sits 1.1-fold (0.03 log units) above what was measured; the range from low to high includes it.
By their numbers in the Homo sapiens assay, from the lowest: compounds 1, 3 and 2 (each within the scatter of the next, the first and the last beyond it).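

Among these compounds, this is the only one-place reading at this aromatic carbon: in the Homo sapiens assay, 1H-pyrazol-1-yl in place of 2H-1,2,3-triazol-2-yl gives a 1.2-fold higher number from compound 1 to compound 3 (0.09 log units; within the scatter), so half-life does not separate the two rings. In a physicochemical assay for solubility, read by nephelometry, in phosphate buffer, measured as kinetic solubility, at pH 6.5 (a lower number here means a less soluble compound, a higher number a more soluble compound), compound 1 gives 25 ug/mL and compound 3 gives 6.3 ug/mL. Solubility, not half-life, is therefore what separates the two rings in this pair: the measured solubility of compound 1, 25 ug/mL, and of compound 3, 6.3 ug/mL, a 4.0-fold lower number (0.60 log units; beyond the scatter)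

The compounds shown leave open how a saturated amine such as morpholine, or a carboxylic acid, on this aromatic carbon would read in the Homo sapiens assay and the physicochemical assay. They also leave open whether the same exchange of rings gives steps of like size on a core without the methyl and fluoro groups.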